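Dropping one methoxy from a triazole thioacetamide

A few compounds are considered here, and "the series" means these few. Any claim that something is new, unique, unknown or untested is made for them only; others in the source may bear on it.

Measured so far:
Compound 1 `C/C(=N\O)c1ccc(NC(=O)CSc2nnc(-c3ccccc3)n2-c2ccccc2)cc1` gives 63% in a functional assay on the whole organism (strain albino) for inhibition, with Rattus norvegicus as the target, read by paw edema, with stated times of 30 min and 3 h, at a dose of 0.28 mmol/kg by the oral route; a lower number here means less inhibition, a higher number more inhibition at the dose given (going by the name of the read-out).
Compound 2 `C=CCn1c(SCC(=O)Nc2ccc(C(C)=O)cc2)nnc1-c1ccc(OC)c(OC)c1` gives 58% in this assay.
Compound 3 `C=CCn1c(SCC(=O)Nc2ccc(/C(C)=N/O)cc2)nnc1-c1ccc(OC)c(OC)c1` gives 70% in this assay.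

Compound 2 stands lowest of the three numbers. Its nearest neighbour is compound 1, a gap within the scatter, so the two cannot be ranked. Compound 3 is furthest, and that step, a number 12 percentage points higher from compound 2 to compound 3 (beyond the scatter), is the only one beyond the scatter; it arises from swapping the acetyl for an oxime on the anilide ring.

Compound 4 `C=CCn1c(SCC(=O)Nc2ccc(C(C)=O)cc2)nnc1-c1ccc(OC)cc1` differs from compound 2 at a different place: hydrogen in place of methoxy on an aromatic carbon. Going by the values given here, no measured step touches this methoxy group, and the one step that is known concerns another part of the molecule, so it cannot tell how removing a methoxy will act. With nothing to point in either direction, the expected step of a number 2 percentage points lower from compound 2 to compound 4 (within the scatter) is one of no change beyond the scatter. Compound 4 is therefore estimated at 56%, with a range from 44% to 68%.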

Compound 4, a percentage reported as inhibition, in the whole organism at one dose (the size of the read-out at that dose, not a potency): 52%
For compound 4 the middle estimate is 4 percentage points above the measured one; measured number inside the range.
By their numbers in this assay, from the lowest: compounds 4, 2, 1 and 3 (each within the scatter of the next, the first and the last beyond it).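

In this assay, cutting the 3,4-dimethoxyphenyl back to 4-methoxyphenyl, with the rest of the molecule held fixed, gives a number 6 percentage points lower from compound 2 to compound 4 (within the scatter). Going by these compounds alone, this is the first reading at this position, and it shows that, in this acetyl compound and at this single dose, hydrogen can stand in place of this methoxy without a difference that can be told from the scatter. Nothing measured here speaks to why the step is this size.

As far as these compounds go, whether the same swap would read the same way in the oxime, compound 3, remains open. Also open, from the compounds shown here alone, is what the remaining methoxy contributes, and what an amine, a chlorine atom or an ethoxy group would do on this same aromatic carbon.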